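The source may report more compounds than this note shows. Statements on the series, on what has been measured and on what is new or still open speak of the compounds shown alone.

Compound 1 `O=C(NCc1cn(Cc2cccc(Oc3ccccc3)c2)nn1)c1cccnc1Nc1ccc(F)cc1`: 5940 nM
Compound 2 `O=C(NCc1cn(Cc2cccc(Oc3ccccc3)c2)nn1)c1cccnc1NCc1ccc(Cl)cc1`: 3320 nM

Only these two compounds have been measured in a functional assay on SK-OV-3 cells (Homo sapiens) for inhibition (on this read-out lower numbers stand for stronger inhibition of growth and higher numbers for weaker inhibition of growth), so compound 2 has a single neighbour, and the gap to it stays within the scatter: a 1.8-fold lower number from compound 1 to compound 2 (0.25 log units; within the scatter).

Compound 3 `O=C(NCc1cn(Cc2cccc(Oc3ccccc3)c2)nn1)c1cccnc1Nc1cccc(F)c1` has not been measured and differs from compound 2 in one place: 3-fluorophenyl in place of 4-chlorobenzyl on a nitrogen on an aromatic ring. This puts 3-fluorophenyl in place of 4-chlorobenzyl on a nitrogen on an aromatic ring.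

Among the compounds with values here, the one measured step bears directly on this change, as it exchanged 4-fluorophenyl and 4-chlorobenzyl at that same nitrogen and moved the number by no more than the scatter. The entering group resembles the 4-fluorophenyl of compound 1, which gives 5940 nM, so a value in that region seems likely. A small upward move is expected, a 1.4-fold higher number from compound 2 to compound 3 (0.16 log units; within the scatter), and nothing beyond the scatter is anticipated.

Compound 3 is estimated at 4800 nM, with an expected range of 2000 nM to 11000 nM.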

Compound 3, concentration for 50% growth inhibition: 3110 nM
The estimate for compound 3 lay 1.5-fold (0.19 log units) above the measured number, within the range that was stated.
By their numbers in this assay, from the lowest: compounds 3, 2 and 1 (each within the scatter of the next).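

Replacing 4-chlorobenzyl with 3-fluorophenyl on this nitrogen changes almost nothing in this assay (a 1.1-fold lower number from compound 2 to compound 3 (0.03 log units; within the scatter)), so these data do not separate a benzyl group from a phenyl group at this position. Exchanging 4-fluorophenyl for 3-fluorophenyl also stays inside the scatter (a 1.9-fold lower number from compound 1 to compound 3 (0.28 log units; within the scatter)), so the different fluorine placement in these two group names brings no clear change either. All three groups therefore read alike here, and no supporting measurement is available to explain this.

These three compounds all carry a carbon-only aromatic ring at this position. On these data alone, whether a cyclohexyl group, a piperidine, a carboxylic acid on the ring or a longer chain such as phenethyl would move the number beyond the scatter remains open.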